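The source may hold more compounds than are shown below. What is called first, only, known or untested is meant among the compounds shown, and "the series" means these compounds.

Measured so far:
compound 1 `CC(C)(Oc1ccc(F)cc1)C1OCC(C/C=C\CCC(=O)O)C(c2cccnc2)O1` — 2000 nM
compound 2 `CC(C)(Oc1ccccc1Br)C1OCC(C/C=C\CCC(=O)O)C(c2cccnc2)O1` — 7000 nM

Compound 2 gives the highest number of the two in an assay for inhibition of prostacyclin synthase (Homo sapiens), using microsomes; a higher number here means a weaker inhibitor, a lower number a stronger inhibitor; its nearest neighbour is compound 1, and the step of a 3.5-fold higher number from compound 1 to compound 2 (0.54 log units; beyond the scatter) is a modest one beyond the scatter. That single step is the only measured one, and it is the one that bears here: it tells that exchanging the 4-fluorophenyl for a 2-bromophenyl on an oxygen on a saturated carbon costs potency.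

Compound 3 `COc1ccc(OC(C)(C)C2OCC(C/C=C\CCC(=O)O)C(c3cccnc3)O2)c([N+](=O)[O-])c1` differs from compound 2 by 4-methoxy-2-nitrophenyl in place of 2-bromophenyl on an oxygen on a saturated carbon. For the measured compounds named here, there is no measured pair in which a 4-methoxy-2-nitrophenyl replaces a 2-bromophenyl, so the step from compound 2 to compound 3 has no direct precedent. Going by the values given here, the one available step, a 3.5-fold higher number from compound 1 to compound 2 (0.54 log units; beyond the scatter), concerns a different swap at the same oxygen, and no further step in this assay is known. The expectation is therefore a small change only, likely within the scatter, in either direction, given as a 1.2-fold lower number from compound 2 to compound 3 (0.07 log units; within the scatter). Compound 3 is expected to give 6000 nM in this assay, within the range 1500 nM to 25000 nM.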

Compound 3, half-maximal inhibitory concentration: 23000 nM
For compound 3 the middle estimate is 3.8-fold (0.58 log units) below the measured one; the range from low to high includes it.
By their numbers in this assay, from the lowest: compound 1; then compound 2; then compound 3.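

Replacing 2-bromophenyl with 4-methoxy-2-nitrophenyl on an oxygen on a saturated carbon gives a 3.3-fold higher number from compound 2 to compound 3 (0.52 log units; beyond the scatter) in this assay, and measured against the 4-fluorophenyl group the same aryl gives a 12-fold higher number from compound 1 to compound 3 (1.06 log units; beyond the scatter) in that read-out. For the compounds shown here, this position therefore spans a wider range than the single earlier step showed, and all three compounds separate beyond the scatter, with the 4-fluorophenyl compound the strongest inhibitor and the 4-methoxy-2-nitrophenyl compound the weakest. No available evidence bears on the origin of this further loss.

The compounds shown do not separate the contributions of the methoxy and nitro parts of the new group. From the compounds shown here alone, it also remains open whether any group at this position improves on compound 1, for instance an unsubstituted phenyl or a phenyl carrying an amine.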